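A New Side Group on the Shared Core

The compounds below may be only part of what the source reports. "The series", "measured", "known", "first", "only" and "open" are said of these compounds alone.

In a physicochemical assay for solubility, read by chemiluminescence, measured as kinetic solubility (on this read-out higher numbers stand for higher solubility and lower numbers for lower solubility), compound 1 `O=C([C@@H]1CCCN1)N1CCC2(CCN(c3nccc(NCc4ccc(Cl)cc4Cl)n3)CC2)C1` gives 165 ug/mL, compound 2 `O=C([C@H]1CCCN1)N1CCC2(CCN(c3nccc(NCc4ccc(Cl)cc4Cl)n3)CC2)C1` gives 180 ug/mL and compound 3 `O=C(C1CCCNC1)N1CCC2(CCN(c3nccc(NCc4ccc(Cl)cc4Cl)n3)CC2)C1` gives 186 ug/mL, so compound 3 stands level with both within the scatter. The change to compound 4 `Clc1ccc(CNc2ccnc(N3CCC4(CCN(CC5CCCN5)C4)CC3)n2)c(Cl)c1` is this: (pyrrolidin-2-yl)methyl in place of (piperidin-3-yl)carbonyl on an amine nitrogen in a ring. The measured ring swap gave a 1.1-fold higher number from compound 1 to compound 3 (0.05 log units; within the scatter) and a 1.0-fold higher number from compound 2 to compound 3 (0.01 log units; within the scatter), while the fact that compounds 1 and 2 differ only in the configuration as drawn goes with a 1.1-fold higher number from compound 1 to compound 2 (0.04 log units; within the scatter). All three steps stay within the scatter, but each keeps the carbonyl that compound 4 lacks, so they guide only loosely. No step beyond the scatter is expected in this assay, and the expected move is a 1.1-fold lower number from compound 3 to compound 4 (0.03 log units; within the scatter). Compound 4 is estimated at 175 ug/mL, with an expected range of 95 ug/mL to 250 ug/mL.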

Compound 4, solubility: 270 ug/mL
For compound 4 the middle estimate is 1.5-fold (0.19 log units) below the measured one; measured number above the stated range.
By their numbers in this assay, from the lowest: compounds 1, 2, 3 and 4 (each within the scatter of the next).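

On this ring nitrogen, removing the carbonyl gives a 1.5-fold higher number from compound 3 to compound 4 (0.16 log units; within the scatter) in this assay, so this link can go without a step beyond the scatter. Compounds 1 and 2 isolate the link better, as they already carry the pyrrolidin-2-yl ring: the change gives a 1.5-fold higher number from compound 2 to compound 4 (0.18 log units; within the scatter) and also a 1.6-fold higher number from compound 1 to compound 4 (0.21 log units; within the scatter) in the same assay. The reading holds from both starting compounds, which matters for one reason: the fact that compounds 1 and 2 differ only in the configuration as drawn.

Still open, from the compounds shown here alone, is whether a plain methyl, an acetyl or a longer chain ending in a carboxylic acid would also stay within the scatter here. Also open, going by these compounds, is how separate drawn configurations of compound 4 would compare.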